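Swapping an Ether Linker for a Benzylamine on a Shared Core

This account rests on a few compounds, and the source may have more. Where it says the series, first, only, none or still open, it means among the compounds named here.

Compound 2, `Nc1cc(N)c2nc(-c3ccccc3)c(Oc3ccc(F)cc3)nc2c1`, is one of three compounds built on a shared core that have been tested in a functional assay on OVCAR-5 cells (Homo sapiens) for inhibition, read by sulforhodamine B assay, with a stated time of 48 h; a higher number here means that more compound is tolerated, a lower number that less compound is tolerated. In this assay compound 2 gives < 100000 nM, which is a limit of the assay rather than a number. Its neighbour compound 1, `Nc1cc(N)c2nc(-c3ccccc3)c(Sc3ccc(F)cc3)nc2c1`, gives < 100000 nM in this assay, again a limit. The step between them, a step that the two limits leave unreadable from compound 1 to compound 2, has no readable size. Compound 3, `CCOC(=O)[C@H](CCC(=O)O)NC(=O)c1ccc(CNc2nc3cc(N)cc(N)c3nc2-c2ccccc2)cc1`, gives < 100000 nM in this assay, also a limit. Compound 2 therefore stands exactly where the other two stand, at the limit of < 100000 nM in this assay, at which 3 of the 3 values shown sit.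

The compound not yet measured is compound 4, `Nc1cc(N)c2nc(-c3ccccc3)c(NCc3ccc(F)cc3)nc2c1`. It differs from compound 2 in one place: (4-fluorobenzyl)amino in place of 4-fluorophenoxy on an aromatic carbon. No measured step can be read for size, so none gives a direction for this change. Among the compounds with values here, compound 3, which carries a different group in place of the 4-fluorophenoxy of compound 2, also sits at the limit, and that is the only guide available. Compound 4 is therefore expected to sit at or near the limit as well, with an expected step that the limit leaves unreadable from compound 2 to compound 4. The estimate for compound 4 is 40000 nM, in the range 8000 nM to 200000 nM.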

Compound 4, concentration lethal to 50% of the cells: < 100000 nM
Compound 4: no number, only a limit; the forecaster's own chance of this, stated with the estimate: 60%; the middle value lies beyond the limit too.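

Compound 4 also gives a limit rather than a number, so neither the step from compound 2 to compound 4 nor the step from compound 1 to compound 4 can be read for size: the limit of < 100000 nM in this assay, at which 4 of the 4 values shown sit. The compounds shown leave open whether compound 1, compound 2 and compound 4 truly differ in this assay, and in which order they would fall.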